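The compounds below may be only part of what the source reports. "The series", "measured", "known", "first", "only" and "open" are said of these compounds alone.

Compound 2 `Cc1ccc(COc2ccc(C(=O)NC(=O)Nc3ccc(C)c(-c4nc5ccccc5[nH]4)c3)cc2)cc1` is one of two substances measured here in a functional assay on HT-29 cells (Homo sapiens) for inhibition, read by MTT assay, with a stated time of 48 h; on this read-out lower numbers stand for stronger inhibition and higher numbers for weaker inhibition. In this assay compound 2 gives 5110 nM. For the measured compounds named here, its only measured neighbour, compound 1 `Cc1ccc(NC(=O)NC(=O)c2ccc(OCc3ccc(C(F)(F)F)cc3)cc2)cc1-c1nc2ccccc2[nH]1`, gives 7830 nM in this assay, and the step of a 1.5-fold lower number from compound 1 to compound 2 (0.19 log units; within the scatter) lies within the usual scatter of the measurement. Compound 3 `Cc1ccc(NC(=O)NC(=O)c2ccc(OCc3ccc(Cl)c(Cl)c3)cc2)cc1-c1nc2ccccc2[nH]1` has not yet been measured; it differs from compound 2 by 3,4-dichlorophenyl in place of 4-methylphenyl on a saturated chain carbon bound to an oxygen on an aromatic ring. Going by the values given here, the only measured step that bears on this position is a 1.5-fold lower number from compound 1 to compound 2 (0.19 log units; within the scatter), which did not move the number beyond the scatter, so a step of a 1.1-fold higher number from compound 2 to compound 3 (0.03 log units; within the scatter) within the scatter is expected. Compound 3 is therefore estimated at 5500 nM, with a range from 2500 nM to 12000 nM.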

Compound 3, half-maximal inhibitory concentration: 1030 nM
For compound 3 the middle estimate is 5.3-fold (0.73 log units) above the measured one; the whole stated range lies above it.
By their numbers in this assay, from the lowest: compound 3; then compounds 2 and 1 (each within the scatter of the next).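

This position is not indifferent to the group it carries: in this assay, 3,4-dichlorophenyl brings a 5.0-fold lower number from compound 2 to compound 3 (0.70 log units; beyond the scatter) and a 7.6-fold lower number from compound 1 to compound 3 (0.88 log units; beyond the scatter), whereas exchanging 4-(trifluoromethyl)phenyl and 4-methylphenyl moved the number only within the scatter. The data give no explanation for this difference. Still open, as far as these compounds go, is whether both chlorines are needed, which a phenyl with a single chlorine would address. Also open, from the compounds shown here alone, is whether an aromatic ring is needed here at all, which a longer chain in its place would address.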